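A few compounds are considered here, and "the series" means these few. Any claim that something is new, unique, unknown or untested is made for them only; others in the source may bear on it.

Compound 2 `COc1ccc([C@H]2CC(=O)N(c3ccc(C)c(N)c3)C2)cc1OC1CCCC1` belongs to a small set of three compounds that share one core and differ only in the group on an amide-type nitrogen in a ring. In a functional assay on HEK293 cells (Homo sapiens) for cytotoxicity (a higher number here means that more compound is tolerated, a lower number that less compound is tolerated), compound 2 gives > 10000 nM, which is a limit of the assay. Compound 1 `COc1ccc([C@H]2CC(=O)N(C(=O)c3ccccc3)C2)cc1OC1CCCC1` gives > 10000 nM in this assay, again a limit. Compound 3 `COc1ccc([C@H]2CC(=O)N(c3cccc(N)c3C)C2)cc1OC1CCCC1` gives > 10000 nM in this assay, also a limit. Because of the limit of > 10000 nM in this assay, at which 3 of the 3 values shown sit, none of the steps between them can be read: a step that the two limits leave unreadable from compound 1 to compound 2, a step that the two limits leave unreadable from compound 1 to compound 3 and a step that the two limits leave unreadable from compound 2 to compound 3 all remain of unknown size, so compound 2 stands level with its two neighbours, with no number to set it apart.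

Compound 4 `COc1ccc([C@H]2CC(=O)N(c3ccc(C(F)(F)F)cc3)C2)cc1OC1CCCC1` changes the group on that nitrogen once more: 4-(trifluoromethyl)phenyl in place of 3-amino-4-methylphenyl on an amide-type nitrogen in a ring. Going by the values given here, no measured step speaks to this change, since all three comparisons sit at the same limit, so no shift beyond the scatter can be expected. The estimated step that the limit leaves unreadable from compound 2 to compound 4 is expected to be flat. Compound 4 is therefore expected to give about 12000 nM, between 5000 nM and 30000 nM, most likely as another limit.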

Compound 4, half-maximal cytotoxic concentration: > 10000 nM
Compound 4: only a limit was reported; the forecaster's own chance of this, stated with the estimate: 80%; the middle value is on the limit's open side.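

Going by these compounds alone, compound 4 gives only a limit, like compound 1, compound 2 and compound 3, so no step from compound 4 to any of them can be read: the limit of > 10000 nM in this assay, at which 4 of the 4 values shown sit. The compounds shown leave open whether any group on that nitrogen changes the result in this assay, and how far beyond the limit each compound lies.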